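A Halogen Swap on the Anilino Ring

A few compounds are considered here, and "the series" means these few. Any claim that something is new, unique, unknown or untested is made for them only; others in the source may bear on it.

Three compounds share one core and differ only in the aryl group carried on the amine nitrogen. In a functional assay on A549 cells (Homo sapiens) for cytotoxicity, read by MTT assay, with a stated time of 48 h (on this read-out higher numbers stand for weaker inhibition and lower numbers for stronger inhibition), compound 1 `COc1ccc(N/C=C\C(=O)c2nc(-c3ccc(C(F)(F)F)cc3)n3ccccc23)cc1OC` gives > 30000 nM, which is a limit of the assay rather than a number. Compound 2 `O=C(/C=C\Nc1ccc2cc[nH]c2c1)c1nc(-c2ccc(C(F)(F)F)cc2)n2ccccc12` likewise gives > 30000 nM, again only a limit. Among the compounds with values here, compound 3 `O=C(/C=C\Nc1ccc(Cl)cc1)c1nc(-c2ccc(C(F)(F)F)cc2)n2ccccc12` gives 18500 nM, the only actual number among the three. Because of the limit of > 30000 nM in this assay, at which 2 of the 3 values shown sit, the step of an at least 1.6-fold lower number from compound 1 to compound 3 (0.20 log units; that floor lies within the scatter) and the step of an at least 1.6-fold lower number from compound 2 to compound 3 (0.20 log units; that floor lies within the scatter) can be read only as floors, and both floors lie within the scatter.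

Compound 4 `O=C(/C=C\Nc1ccc(F)cc1)c1nc(-c2ccc(C(F)(F)F)cc2)n2ccccc12` differs from compound 3 by fluoro in place of chloro on an aromatic carbon. Within the data shown here, no measured step swaps one halogen for another at this place; the two steps that touch the same aryl group replace whole substituent patterns and set only floors. One therefore expects little movement beyond the scatter in this assay, with a slight lean toward a weaker number, and a real chance that the assay reports only a limit. The estimate for compound 4 is 22000 nM, between 9000 nM and 50000 nM, which corresponds to an expected step of a 1.2-fold higher number from compound 3 to compound 4 (0.08 log units; within the scatter).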

Compound 4, half-maximal inhibitory concentration: > 30000 nM
Compound 4 ended at the assay's limit; the forecaster's own chance of this, stated with the estimate: 35%; middle value at least 1.3-fold (0.13 log units) from the limit.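

This is the only direct exchange of one halogen for another shown at this place, on an aromatic carbon para to a large group, and in this assay compound 4 gives > 30000 nM, which is a limit of the assay and not a number. Fluoro in place of chloro gives an at least 1.6-fold higher number from compound 3 to compound 4 (0.20 log units; that floor lies within the scatter), so this exchange has only a floor and no measured size, and the data do not separate the two halogens beyond the scatter. The steps from compound 1 and from compound 2 to compound 4 cannot be read, and the comparison can go no further because of a single ceiling: the limit of > 30000 nM in this assay, at which 3 of the 4 values shown sit.

As far as these compounds go, it remains open whether bromo, methyl or a single methoxy group at this place would give an actual number in this assay, and whether chloro would stand apart from such groups. Also open, from the compounds shown here alone, is whether replacing the trifluoromethyl group on the shared core with a nitrile would bring the 4-fluorophenyl and 4-chlorophenyl compounds into a range where both could be read as numbers.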